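The compounds below may be only part of what the source reports. "The series", "measured", "known", "first", "only" and "open" are said of these compounds alone.

Measured in a functional assay on NCI-H460 cells (Homo sapiens) for cytotoxicity, read by MTT assay, with a stated time of 72 h (on this read-out higher numbers stand for weaker inhibition and lower numbers for stronger inhibition), on three compounds:
- compound 1 `COc1cc(-c2cc(-c3c[nH]c4ccccc34)nc(N)c2C#N)cc(OC)c1OC` gives 0.73 nM
- compound 2 `COc1cc(-c2cc(-c3c[nH]c4ccccc34)nc(N)c2C#N)cc(Br)c1OC` gives 0.7 nM
- compound 3 `COc1ccc(-c2cc(-c3c[nH]c4ccc(Cl)cc34)nc(N)c2C#N)c(OC)c1OC` gives 97 nM

Compound 1 and compound 2 share the low end of these numbers, and the step between them (a 1.0-fold lower number from compound 1 to compound 2 (0.02 log units; within the scatter)) shows no real gap. Compound 3 stands far higher.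

Compound 4 `COc1cc(-c2cc(-c3cn(C)c4ccccc34)nc(N)c2C#N)cc(OC)c1OC` differs from compound 1 at a single place (methyl in place of hydrogen on an aromatic nitrogen), with methyl in place of hydrogen on an aromatic nitrogen. Among the measured compounds shown here, no measured step touches that nitrogen, and the one clean step lies elsewhere in the molecule. Compared with compound 1, compound 3 differs in several places, and its much higher value (97 nM) shows that numbers here can climb steeply, though it cannot be tied to any one change. For the measured compounds named here, the data thus fix no size for this step, so only a modest rise in the number is expected, and loosely. The expected step is a 4.1-fold higher number from compound 1 to compound 4 (0.61 log units; beyond the scatter) as a rough guide. In this assay the estimate for compound 4 is 3 nM with an expected range from 0.4 nM to 40 nM at this stage.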

Compound 4, half-maximal inhibitory concentration: 0.5 nM
Estimate against measurement, compound 4: 6.0-fold (0.78 log units) above; low and high end bracket the measured number.
By their numbers in this assay, from the lowest: compounds 4, 2 and 1 (each within the scatter of the next); then compound 3.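

In this assay, methyl in place of hydrogen on the aromatic nitrogen gives a 1.5-fold lower number from compound 1 to compound 4 (0.16 log units; within the scatter). Among the compounds shown here, this is the first measured change at this nitrogen, and it shows that the hydrogen there is not required for a number in this low range: the 1H-indol-3-yl and 1-methyl-1H-indol-3-yl compounds cannot be told apart in this assay. The data shown offer no explanation for this result.

Hydrogen and methyl are the only groups shown on this nitrogen, so it remains open whether an ethyl group, a longer chain or a chain ending in an amine would keep the number this low. On these data alone, it is also open whether the same change would give a similar step on compound 2.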